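The source may hold more compounds than are shown below. What is called first, only, known or untested is meant among the compounds shown, and "the series" means these compounds.

In an ADME assay on L02 cells (Homo sapiens) for cytotoxicity, read by MTT assay, with a stated time of 24 h (a higher number here means a weaker inhibitor, a lower number a stronger inhibitor), compound 1 `O=C1/C(=C/c2cccnc2)CNC/C1=C\c1ccccc1C(F)(F)F` gives 11300 nM. Compound 2 `O=C1/C(=C/c2cccnc2)CN(S(=O)(=O)c2ccccc2)C/C1=C\c1ccccc1C(F)(F)F`, which has phenylsulfonyl in place of hydrogen on an amine nitrogen in a ring, gives 12500 nM. On these two numbers, compound 2 stands level with compound 1, since the gap between them lies within the scatter of repeated measurements.

Compound 3 `Cc1ccc(S(=O)(=O)N2C/C(=C\c3cccnc3)C(=O)/C(=C/c3ccccc3C(F)(F)F)C2)cc1` has not yet been measured. Its structure differs from that of compound 2 by one small change: methyl in place of hydrogen on an aromatic carbon. Methyl takes the place of hydrogen on an aromatic carbon, so phenylsulfonyl becomes (4-methylphenyl)sulfonyl.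

Going by the values given here, only one measured step bears on this change, and it involves the same group: installing the whole phenylsulfonyl produced a 1.1-fold higher number from compound 1 to compound 2 (0.04 log units; within the scatter). That step stayed within the scatter, so a single added methyl is expected to produce no step beyond the scatter in this assay, in either direction. The step expected is a 1.0-fold lower number from compound 2 to compound 3 (0.02 log units; within the scatter). With just one step to go on, the expected range is kept wide. The estimate for compound 3 is 12000 nM, with a range from 6500 nM to 22000 nM.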

Compound 3, half-maximal inhibitory concentration: 12300 nM
Beside the measured number, compound 3's estimate is 1.0-fold (0.01 log units) below it; the range from low to high includes it.
By their numbers in this assay, from the lowest: compounds 1, 3 and 2 (each within the scatter of the next).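

In this assay, the outer end of the sulfonyl group now has its first test: methyl in place of hydrogen on an aromatic carbon, para to a large group, gives a 1.0-fold lower number from compound 2 to compound 3 (0.01 log units; within the scatter) and so leaves the number level. Measured against the unsubstituted amine, the whole (4-methylphenyl)sulfonyl group gives a 1.1-fold higher number from compound 1 to compound 3 (0.04 log units; within the scatter) and thus, like phenylsulfonyl, stands level with hydrogen on the amine nitrogen in the ring. Nothing available here offers a reason for these level numbers.

The compounds shown place only hydrogen or methyl at this aromatic carbon, so it stays open whether a methoxy group, an amine or a carboxylic acid there would move the number beyond the scatter. On these data alone, it also stays open whether an acetyl group or a longer alkyl chain on the amine nitrogen, in place of the sulfonyl groups, would stand level with compound 1 in the same way.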